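A few compounds are considered here, and "the series" means these few. Any claim that something is new, unique, unknown or untested is made for them only; others in the source may bear on it.

Measured so far:
compound 1, `CCCCCCCCCCc1ccc(-c2noc(C3CNC3)n2)cc1`, 65%
compound 2, `CCCCCCCCCCc1ccc(-c2noc(CCCNC)n2)cc1`, 45%
compound 3, `CCCCCCCCCCc1ccc(-c2noc(CC[C@@H](N)C(=O)O)n2)cc1`, 5%

Three compounds share one core and differ only in the group on an aromatic carbon of the five-membered aromatic ring. In an assay on HeLa cells for inhibition of sphingosine-1-phosphate transporter SPNS2 (Mus musculus), read by LC-MS, tested at 2 uM (a lower number here means less inhibition, a higher number more inhibition at the concentration tested (going by the name of the read-out)), compound 1 gives 65%, compound 2 gives 45% and compound 3 gives 5%. Compound 2 stands second of the three: its nearest neighbour is compound 1, with a number 20 percentage points lower from compound 1 to compound 2 (beyond the scatter), and the furthest is compound 3, with a number 40 percentage points lower from compound 2 to compound 3 (beyond the scatter). The step of a number 60 percentage points lower from compound 1 to compound 3 (beyond the scatter) completes the picture.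

Compound 4, `CCCCCCCCCCc1ccc(-c2noc(C(Cl)CCN)n2)cc1`, has not been measured. It differs from compound 2 as follows: a group of 5 heavy atoms (3 carbon, 1 nitrogen, 1 chlorine; no ring) in place of a group of 5 heavy atoms (4 carbon, 1 nitrogen; no ring), on an aromatic carbon. Both measured steps that touch this position bear on it. The modest one, a number 20 percentage points lower from compound 1 to compound 2 (beyond the scatter), shows that exchanging one amine-bearing chain for another moves the number only a little; the large one, a number 40 percentage points lower from compound 2 to compound 3 (beyond the scatter), belongs to a change that brings in a carboxy group, which compound 4 does not carry. The entering group keeps an amine and has no ring, like the leaving group. Compound 4 is therefore expected to land close to compound 2, with a number 5 percentage points lower from compound 2 to compound 4 (within the scatter), and the estimate for compound 4 is 40%, between 15% and 65%.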

Compound 4, a percentage reported as inhibition, at one concentration (the size of the read-out at that concentration, not a potency): 5%
Compound 4: middle estimate off by 35 percentage points, on the high side; measured number below the stated range.
By their numbers in this assay, from the lowest: compounds 3 and 4 (each within the scatter of the next); then compound 2; then compound 1.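

In this assay, exchanging 3-(methylamino)propyl for the chlorine-bearing group of the same heavy-atom count gives a number 40 percentage points lower from compound 2 to compound 4 (beyond the scatter), so at this position on the five-membered aromatic ring, keeping an amine and staying without a ring does not by itself preserve the number. A carboxy group is also not needed for a low number here, since the comparison with the 3-amino-3-carboxypropyl group gives no change at the digits printed from compound 3 to compound 4 (within the scatter), even though the entering group carries an amine and no carboxy group. Against the azetidin-3-yl group, the same chlorine-bearing group gives a number 60 percentage points lower from compound 1 to compound 4 (beyond the scatter), which shows that among the amine-bearing groups compared here, the presence of an amine does not settle the outcome.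

Nothing available here explains why this change lowers the number. From the compounds shown here alone, since the chlorine-bearing group differs from 3-(methylamino)propyl in more than the chlorine, it remains open what a 3-aminopropyl group without chlorine, or a group with fluorine in place of the chlorine, would give.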